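The source may report more compounds than this note shows. Statements on the series, on what has been measured and on what is new or still open speak of the compounds shown alone.

Compound 1 `O=C(O)C[C@H](O)C[C@H](O)CCn1c(-c2ccc(F)cc2)nc(C(=O)NCc2ccccc2F)c1C1CC1`: 1.5 nM
Compound 2 `O=C(O)C[C@H](O)C[C@H](O)CCn1c(-c2ccc(F)cc2)nc(C(=O)NCc2cccc(F)c2)c1C1CC1`: 1.2 nM

Both compounds were tested in an assay on microsomes from liver for inhibition of 3-hydroxy-3-methylglutaryl-coenzyme A reductase (Rattus norvegicus), read by scintillation counting, with stated times of 0.5 h and 0.75 h; a lower number here means a stronger inhibitor, a higher number a weaker inhibitor. Compound 1 gives 1.5 nM, and compound 2 gives 1.2 nM. For the measured compounds named here, the step of a 1.3-fold lower number from compound 1 to compound 2 (0.10 log units; within the scatter) is the only measured step here, and it lies within the scatter: the two values cannot be told apart. Compound 2 therefore holds the lowest of the two numbers, but nothing can be said about an order between it and compound 1.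

Compound 3 `O=C(O)C[C@H](O)C[C@H](O)CCn1c(-c2ccc(F)cc2)nc(C(=O)NCc2ccc(F)cc2)c1C1CC1` has not yet been measured. It differs from compound 2 by 4-fluorophenyl in place of 3-fluorophenyl on a saturated chain carbon bound to an amide-type nitrogen. Going by the values given here, this is the same kind of change as the one from compound 1 to compound 2, where the fluorine on the benzyl group moved from one ring position to another, and that step a 1.3-fold lower number from compound 1 to compound 2 (0.10 log units; within the scatter) stayed within the scatter. Among the compounds with values here, the only relevant step thus points to no change beyond the scatter, and the expected step of a 1.1-fold higher number from compound 2 to compound 3 (0.03 log units; within the scatter) is correspondingly small. For compound 3 the estimated value in this assay is 1.3 nM, expected to fall between 0.5 nM and 3.5 nM.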

Compound 3, half-maximal inhibitory concentration: 3.4 nM
The estimate for compound 3 lay 2.6-fold (0.42 log units) below the measured number, and the stated range covers the measured number.
By their numbers in this assay, from the lowest: compounds 2 and 1 (each within the scatter of the next); then compound 3.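

Where the fluorine sits on this ring does matter at this place on the saturated chain carbon bound to the amide nitrogen: in this assay, the change to 4-fluorophenyl gives a 2.8-fold higher number from compound 2 to compound 3 (0.45 log units; beyond the scatter), and the same group in place of 2-fluorophenyl gives a 2.3-fold higher number from compound 1 to compound 3 (0.36 log units; beyond the scatter). The earlier step between 2-fluorophenyl and 3-fluorophenyl stayed within the scatter and hinted at no effect from moving the fluorine, whereas the 4-fluorobenzyl amide now stands apart from those two, by modest steps in both cases. No measurement at hand speaks to the reason for this gap.

On these data alone, all three compounds carry a fluorine on the benzyl ring, so it remains open how a plain benzyl group would compare, and whether chlorine or a methoxy group would show the same dependence on ring location. Also open, as far as these compounds go, is what happens with a longer chain between the amide nitrogen and the ring, or with an amine or a carboxylic acid on the ring in place of the fluorine.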